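Replacing the carbamoylmethoxy side chain with a cyclic amine

The source may report more compounds than this note shows. Statements on the series, on what has been measured and on what is new or still open speak of the compounds shown alone.

Measured compounds:
compound 1 `CCNC(=O)c1noc(-c2cc(C(C)C)c(O)cc2O)c1-c1cc(CO)no1` — 13 nM
compound 2 `CCNC(=O)c1noc(-c2cc(C(C)C)c(O)cc2O)c1-c1cc(COCC(N)=O)no1` — 97 nM
compound 3 `CCCNCc1cc(-c2c(C(=O)NCC)noc2-c2cc(C(C)C)c(O)cc2O)on1` — 117 nM

The three compounds share a core and differ only in the group attached to the saturated chain carbon bound to an aromatic carbon. In a functional assay on HCT-116 cells (Homo sapiens) for inhibition (a higher number here means a weaker inhibitor, a lower number a stronger inhibitor), compound 1 gives 13 nM and stands alone at the low end. Compound 2 sits second highest of the three numbers; its nearest neighbour is compound 3, at a gap a 1.2-fold higher number from compound 2 to compound 3 (0.08 log units; within the scatter), and its furthest is compound 1, at a 7.5-fold higher number from compound 1 to compound 2 (0.87 log units; beyond the scatter). The other step from the hydroxymethyl parent, a 9.0-fold higher number from compound 1 to compound 3 (0.95 log units; beyond the scatter), is of much the same size, so either larger group on this carbon costs a modest amount relative to compound 1, while the two larger groups themselves sit within the scatter of each other.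

The next compound, compound 4 `CCNC(=O)c1noc(-c2cc(C(C)C)c(O)cc2O)c1-c1cc(CN2CCN(C)CC2)no1`, carries the change (4-methylpiperazin-1-yl in place of carbamoylmethoxy on a saturated chain carbon bound to an aromatic carbon); cut one bond further out, this reads (carbamoylmethoxy)methyl to (4-methylpiperazin-1-yl)methyl. For the measured compounds named here, the step that bears most directly on it is the one to compound 3, a 1.2-fold higher number from compound 2 to compound 3 (0.08 log units; within the scatter), where another nitrogen-bearing group in this place left the number where it was. On that basis the step of a 1.0-fold higher number from compound 2 to compound 4 (0.01 log units; within the scatter) is expected to stay within the scatter. Compound 4 is therefore estimated at 100 nM in this assay, with a range from 40 nM to 300 nM.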

Compound 4, half-maximal inhibitory concentration: 340 nM
Compound 4: middle estimate off by 3.4-fold (0.53 log units), on the low side; the measured number lies above the stated range.
By their numbers in this assay, from the lowest: compound 1; then compounds 2 and 3 (each within the scatter of the next); then compound 4.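

Not every nitrogen-bearing group behaves alike at this place: in this assay the 4-methylpiperazin-1-yl group separates from both carbamoylmethoxy (a 3.5-fold higher number from compound 2 to compound 4 (0.54 log units; beyond the scatter)) and propylamino (a 2.9-fold higher number from compound 3 to compound 4 (0.46 log units; beyond the scatter)), although those two could not be told apart. For the compounds shown here, compound 4 therefore stands as the weakest of the four, and the distance from the hydroxymethyl parent (a 26-fold higher number from compound 1 to compound 4 (1.42 log units; beyond the scatter)) is the only step from that parent graded large, so the larger groups on this saturated chain carbon are not interchangeable. No accompanying measurement accounts for this difference, and the step remains an observation without an explanation.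

From the compounds shown here alone, it remains open whether the ring itself or its methyl group carries the step, a question that piperazin-1-yl, morpholin-4-yl or dimethylamino on the same carbon would help to separate. Going by these compounds, it is also open whether any larger group here can return towards compound 1 (13 nM), for example a carboxylic acid or a longer chain ending in a hydroxy group.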